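The source may hold more compounds than are shown below. What is called first, only, known or untested is meant among the compounds shown, and "the series" means these compounds.

Compound 1, `c1ccc2c(c1)CN[C@@H](CN(CCCCNCC1CCCCC1)[C@H]1CCCc3cccnc31)C2`, stands as the weaker of the two measured entries: in a functional assay on cells for antagonist activity at C-X-C chemokine receptor type 4 (Homo sapiens), read by fluorescence and calcium flux, with stated times of 25 min and 90 s (on this read-out higher numbers stand for weaker inhibition and lower numbers for stronger inhibition), compound 1 gives 158 nM, while compound 2, `C(=C/CN(C[C@H]1Cc2ccccc2CN1)[C@H]1CCCc2cccnc21)\CNCc1ccccn1`, gives 58.3 nM. Going by the values given here, the only measured step, a 2.7-fold lower number from compound 1 to compound 2 (0.43 log units; beyond the scatter), exchanges the ring-bearing end of the chain, on a saturated chain carbon bound to an amine nitrogen, and brings a modest gain. Compound 3, `CC(C)(CCN(C[C@H]1Cc2ccccc2CN1)[C@H]1CCCc2cccnc21)CNCC1CCOCC1`, alters the same region of compound 1 in a different way: a group of 12 heavy atoms (10 carbon, 1 nitrogen, 1 oxygen; one six-membered non-aromatic ring with 1 hetero atom) in place of a group of 10 heavy atoms (9 carbon, 1 nitrogen; one six-membered non-aromatic ring of carbon only), on a saturated chain carbon, two bonds along the chain from an amine nitrogen. Among the compounds with values here, the one recorded step suggests that changes at this end of the chain shift the number only modestly, so for compound 3 the expected step is a 1.4-fold lower number from compound 1 to compound 3 (0.16 log units; within the scatter), a small move toward a lower number that may well fall within the scatter. Compound 3 is therefore estimated at 110 nM, with a range from 40 nM to 300 nM.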

Compound 3, half-maximal inhibitory concentration: 43.8 nM
Estimate against measurement, compound 3: 2.5-fold (0.40 log units) above, and the stated range covers the measured number.
By their numbers in this assay, from the lowest: compounds 3 and 2 (each within the scatter of the next); then compound 1.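

In this assay, replacing the 2-((cyclohexylmethyl)amino)ethyl group with a group of 12 heavy atoms, whose six-membered non-aromatic ring holds one hetero atom, gives a 3.6-fold lower number from compound 1 to compound 3 (0.56 log units; beyond the scatter). The earlier step at this end of the chain, a 2.7-fold lower number from compound 1 to compound 2 (0.43 log units; beyond the scatter), brought in an aromatic ring, so a lower number beyond the scatter now also appears with a non-aromatic ring containing a hetero atom. No measurement at hand accounts for either step.

Going by these compounds, the entering group differs from the leaving one in more than its ring, and what the ring oxygen contributes on its own remains open. Also open, on these data alone, is how a piperidine ring or a carboxylic acid at this end of the chain would read in this assay.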